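From chloro to methyl: expected plasma binding of compound 4

The compounds below may be only part of what the source reports. "The series", "measured", "known", "first", "only" and "open" are said of these compounds alone.

In an ADME assay on a cell-free system (plasma, Mus musculus) for protein binding, read by LC-MS, with a stated time of 4 h, tested at 1 ug/mL, compound 1 (`CN1CCNC(=O)COc2ccc(F)cc2C(=O)N2CCCC[C@H]2c2cc3nc(N4CCC4)cc1n3n2`) gives 98% and compound 2 (`Cc1ccc2c(c1)C(=O)N1CCCCC1c1cc3nc(N4CCC4)cc(n3n1)N(C)CCNC(=O)CO2`) gives 96.9%. Compound 3 (`CN1CCNC(=O)COc2ccc(Cl)cc2C(=O)N2CCCC[C@H]2c2cc3nc([C@H]4C[C@H](O)C4)cc1n3n2`) gives 85.5%, which leaves it the largest free share of the three, and its gap to each of the other two lies beyond the scatter.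

Compound 4 (`Cc1ccc2c(c1)C(=O)N1CCCC[C@H]1c1cc3nc([C@H]4C[C@H](O)C4)cc(n3n1)N(C)CCNC(=O)CO2`) has not been measured yet. It differs from compound 3 in one place, with methyl in place of chloro on an aromatic carbon. Within the data shown here, no two measured compounds differ in one place only, so the data offer no direct precedent for this swap. The expectation therefore starts from compound 3 at 85.5% and stays close to it, since one heavy atom simply replaces another. The expected step, a 1.1-fold higher unbound fraction from compound 3 to compound 4 (0.04 log units; within the scatter), is none beyond the scatter of this assay. For compound 4 the estimated value is 84%, with an expected range from 72% to 92%.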

Compound 4, plasma protein binding: 77.8%
Compound 4: middle estimate off by 1.4-fold (0.14 log units) (unbound fraction), on the low side, within the range that was stated.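

In this assay, among these compounds, methyl in place of chloro on an aromatic carbon gives a 1.5-fold higher unbound fraction from compound 3 to compound 4 (0.18 log units; within the scatter), and this is the first pair here that differs in one place only. At this carbon of the six-membered aromatic ring, chloro and methyl, each a single heavy atom, therefore cannot be told apart by plasma binding on this core. Nothing shown here gives a measured reason for the size of this step.

Still open, as far as these compounds go, is how a larger or charged group at the same carbon, such as a nitrile, an amine or a carboxylic acid, would read in this assay. This single pair also cannot show whether methyl and chloro would remain indistinguishable with a different group elsewhere on the core.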